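From 4-acetylphenyl to 4-chlorophenyl on the shared core

This account rests on a few compounds, and the source may have more. Where it says the series, first, only, none or still open, it means among the compounds named here.

Of the compounds shown here, three have values so far in a functional assay on B16 cells (Mus musculus) for cytotoxicity, read by MTT assay, with a stated time of 48 h (on this read-out higher numbers stand for weaker inhibition and lower numbers for stronger inhibition), and all sit in a narrow band. Compound 1 `CC1(C)CCCC2=CC=C(C=O)CC[C@]21C` gives 145000 nM here, compound 3 `C=C1CCC[C@]2(C)CCC(c3cn(CC(=O)Nc4ccc(C)cc4)nn3)=CC[C@@]12C` gives 210000 nM here, and compound 2 `C=C1CCC[C@]2(C)CCC(c3cn(-c4ccc(C(C)=O)cc4)nn3)=CC[C@@]12C` gives 61000 nM as the lowest number of the three, beyond the scatter from both others.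

Compound 4 `C=C1CCC[C@]2(C)CCC(c3cn(-c4ccc(Cl)cc4)nn3)=CC[C@@]12C` keeps the core of compound 2 and is the next to be read. The change is chloro in place of acetyl on an aromatic carbon and amounts to chloro in place of acetyl on an aromatic carbon, with 4-acetylphenyl becoming 4-chlorophenyl.

Among the compounds with values here, no two measured compounds differ in one place, so the size of this step has no direct precedent. On the same core, compound 3 at 210000 nM and compound 2 at 61000 nM lie only modestly apart, so a large move is not expected. The expected outcome is a 1.4-fold higher number from compound 2 to compound 4 (0.14 log units; within the scatter) as a slight rise in the number, not beyond the scatter. Compound 4 is estimated at 85000 nM with a range from 35000 nM to 200000 nM expected on this evidence.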

Compound 4, half-maximal inhibitory concentration: 27200 nM
For compound 4 the middle estimate is 3.1-fold (0.49 log units) above the measured one, and the stated range ends above it.
By their numbers in this assay, from the lowest: compound 4; then compound 2; then compounds 1 and 3 (each within the scatter of the next).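

Within the data shown here, this is the first step that changes a single place. In this assay, chloro in place of acetyl on an aromatic carbon, para to a large group, gives a 2.2-fold lower number from compound 2 to compound 4 (0.35 log units; beyond the scatter). The position is therefore not indifferent to its substituent, and here one heavy atom with no hydrogen-bond acceptor in place of three heavy atoms with one goes with the lower number, though this rests on one pair. No measured evidence bears on why the number falls.

As far as these compounds go, whether the lower number follows the chloro group itself or the removal of the acetyl group stays open. Fluoro, methoxy, an amine or a carboxylic acid at this same place, or a plain phenyl with no substituent, would help separate these two readings.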